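Vero cell cytotoxicity: working notes toward compound 4

A few compounds are considered here, and "the series" means these few. Any claim that something is new, unique, unknown or untested is made for them only; others in the source may bear on it.

The three measured compounds share one core and differ only in the group on an amine nitrogen attached to the ring amine. Compound 1 `O=c1nc(N2CCN(NC3CCCCC3)CC2)sc2c([N+](=O)[O-])cc(C(F)(F)F)cc12` carries cyclohexyl there. Compound 2 `CON=C1CCC(N(C)N2CCN(c3nc(=O)c4cc(C(F)(F)F)cc([N+](=O)[O-])c4s3)CC2)CC1` carries a larger group in its place. Compound 3 `O=c1nc(N2CCN(NCc3cc(F)cc(F)c3)CC2)sc2c([N+](=O)[O-])cc(C(F)(F)F)cc12` carries 3,5-difluorobenzyl. In an ADME assay on Vero cells (Chlorocebus sabaeus) for cytotoxicity, read by MTT assay, with a stated time of 72 h (on this read-out lower numbers stand for higher toxicity in this test and higher numbers for lower toxicity in this test), compound 1 gives > 64 ug/mL, a limit of the assay and not a number. In this assay compound 2 gives > 64 ug/mL, again a limit. In this assay compound 3 gives > 64 ug/mL, also a limit. Compound 2 therefore stands at the same limit as the other two, with no number to place it apart from them.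

Compound 4 `CN(c1ccc(OC(F)(F)F)cc1)N1CCN(c2nc(=O)c3cc(C(F)(F)F)cc([N+](=O)[O-])c3s2)CC1` differs from compound 2 by a group of 11 heavy atoms (7 carbon, 1 oxygen, 3 fluorine; one six-membered aromatic ring of carbon only) in place of a group of 9 heavy atoms (7 carbon, 1 nitrogen, 1 oxygen; one six-membered non-aromatic ring of carbon only), on an amine nitrogen. Among the measured compounds shown here, the steps that bear on this change are a step that the two limits leave unreadable from compound 1 to compound 2, a step that the two limits leave unreadable from compound 2 to compound 3 and a step that the two limits leave unreadable from compound 1 to compound 3; none of them can be read in size. For the measured compounds named here, every value so far sits at the limit of > 64 ug/mL in this assay, at which 3 of the 3 values shown sit. Nothing among the three measured compounds points to a step beyond the scatter in either direction, so a reading at the limit again is the likeliest outcome, with the step that the limit leaves unreadable from compound 2 to compound 4 expected to be small. Compound 4 is accordingly estimated at 80 ug/mL, within 40 ug/mL to 160 ug/mL.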

Compound 4, half-maximal cytotoxic concentration: > 64 ug/mL
Compound 4 gave a limit, no number; the forecaster's own chance of this, stated with the estimate: 75%; the middle value is on the limit's open side.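

In this assay compound 4 gives > 64 ug/mL, a limit of the assay and not a number, so no new step can be read between compound 2 and compound 4. The compounds shown leave open whether changing the group on the amine nitrogen moves the cytotoxicity read-out at all, as every value stands at one limit: the limit of > 64 ug/mL in this assay, at which 4 of the 4 values shown sit.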